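From cyclobutyl to 3-chlorophenyl at the ring amine

The compounds below may be only part of what the source reports. "The series", "measured", "known", "first", "only" and "open" are said of these compounds alone.

Compound 1 `COc1cc(N)c(Cl)cc1NC(=O)C1CCN(CC2CCC2)CC1` is the starting point of this account. In a functional assay on the whole organism for antagonist activity, with Mus musculus as the target (on this read-out lower numbers stand for an effect already at smaller amounts and higher numbers for an effect only at larger amounts of compound), compound 1 gives only a limit of the assay, > 10 mg/kg. Compound 2 `CCN1CCC(C(=O)Nc2cc(Cl)c(N)cc2OC)CC1` differs from it in one place, methyl in place of cyclobutyl on a saturated chain carbon bound to an amine nitrogen in a ring. In this assay compound 2 likewise reaches only a limit, > 10 mg/kg. The step that the two limits leave unreadable from compound 1 to compound 2 therefore cannot be read, and all that the two measured compounds share is the limit of > 10 mg/kg in this assay, at which 2 of the 2 values shown sit. Compound 3 `COc1cc(N)c(Cl)cc1NC(=O)C1CCN(Cc2cccc(Cl)c2)CC1` carries the change (3-chlorophenyl in place of cyclobutyl on a saturated chain carbon bound to an amine nitrogen in a ring). Going by the values given here, no measured step bears on this change: the single step between measured compounds is unreadable, and it concerns a different replacement. Compound 1 sits at the limit, so any readable number for compound 3 would have to come in lower than that. Compound 3 is expected to give 10 mg/kg in this assay, with a range from 3 mg/kg to 30 mg/kg, though a further limit is the more probable outcome. Among the compounds with values here, the step of a number no higher from compound 1 to compound 3 (the limit leaves the size open) is thus an expectation only, resting on no measured step.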

Compound 3, dose for half-maximal effect: > 4 mg/kg
Compound 3 was reported as a limit; the forecaster's own chance of this, stated with the estimate: 60%; the middle value lies beyond the limit too.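

In this assay compound 3 gives > 4 mg/kg, which is again a limit and not a number. The steps from compound 1 to compound 3 and from compound 2 to compound 3 therefore cannot be read. The compounds shown leave open how far compound 1, compound 2 and compound 3 differ in this assay, and whether any of them reaches a readable dose there.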